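The source may hold more compounds than are shown below. What is called first, only, known or untested is meant among the compounds shown, and "the series" means these compounds.

Of the compounds shown here, three sharing one core have been tested in an assay on isolated protein for inhibition of tyrosine-protein kinase receptor UFO (Homo sapiens), read by LC-MS; on this read-out higher numbers stand for weaker inhibition and lower numbers for stronger inhibition. Compound 1 `CN(Cc1ccc2nccn2c1)c1nnc(-c2ccccc2)o1` carries an unsubstituted phenyl on the core. In this assay compound 1 reaches only the limit > 100000 nM, a bound of the measurement rather than a number (the limit of > 100000 nM in this assay, at which 1 of the 3 values shown sits). Compound 2 `CN(Cc1ccc2nccn2c1)c1nnc(-c2ccc(C3CC3)cc2)o1` carries a cyclopropyl on an aromatic carbon and in this assay gives 20000 nM, while compound 3 `CN(Cc1ccc2nccn2c1)c1nnc(-c2ccc(-c3ccccc3)cc2)o1` carries a phenyl at that carbon and gives 3160 nM. Compound 3 thus holds the lowest of the two numbers that could be counted, its nearest neighbour being compound 2, from which it is set apart by the step of a 6.3-fold lower number from compound 2 to compound 3 (0.80 log units; beyond the scatter); the step of an at least 5.0-fold lower number from compound 1 to compound 2 (0.69 log units; beyond the scatter) and the step of an at least 31-fold lower number from compound 1 to compound 3 (1.50 log units; beyond the scatter) both lead away from the limit of compound 1.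

Compound 4 `CN(Cc1ccc2nccn2c1)c1nnc(-c2ccc(-c3ccccc3F)cc2)o1` differs from compound 3 by fluoro in place of hydrogen on an aromatic carbon, that is, phenyl to 2-fluorophenyl. Among the compounds with values here, none of the measured steps exchanges a hydrogen for a fluoro; all three alter the whole group on the aromatic carbon, and each of them lay beyond the scatter. A single fluoro on the outer ring is a far smaller alteration than any of those, so the expectation for compound 4 in this assay is a step of a 1.3-fold lower number from compound 3 to compound 4 (0.10 log units; within the scatter) that stays within the scatter. Compound 4 is therefore estimated at 2500 nM, expected between 900 nM and 8000 nM.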

Compound 4, half-maximal inhibitory concentration: 1580 nM
Estimate against measurement, compound 4: 1.6-fold (0.20 log units) above; measured number inside the range.
By their numbers in this assay, from the lowest: compounds 4 and 3 (each within the scatter of the next); then compound 2. At a limit, above all of these: compound 1.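

In this assay, within the data shown here, this is the first change made on the outer ring itself rather than to the whole group on the aromatic carbon, and fluoro in place of hydrogen, ortho to a large group, gives a 2.0-fold lower number from compound 3 to compound 4 (0.30 log units; within the scatter), so this position accepts a fluoro while compound 3 and compound 4 cannot be told apart. The 2-fluorophenyl group also keeps the outer ring's clear lead over the smaller groups on that carbon, with a 13-fold lower number from compound 2 to compound 4 (1.10 log units; beyond the scatter) and an at least 63-fold lower number from compound 1 to compound 4 (1.80 log units; beyond the scatter). Compound 1 stands at a limit, so the last of these steps is a bound and not an exact size: the limit of > 100000 nM in this assay, at which 1 of the 4 values shown sits.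

What the compounds shown leave open is whether this position tolerates only a single fluoro, or whether a chloro, a methoxy, a trifluoromethyl, an amine or a carboxylic acid in its place would carry the number beyond the scatter in either direction. They also leave open how a fluoro would read on the other carbons of the outer ring, and whether a second fluoro would add anything to the first.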